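One More Substituent Swap at the Assay Limit

The compounds below may be only part of what the source reports. "The series", "measured", "known", "first", "only" and "open" are said of these compounds alone.

Measured so far:
Compound 1 `CC(=O)Nc1cc(NC(=O)Nc2ccccc2Cl)ccc1C`: in a functional assay on A375P cells (Homo sapiens) for antiproliferative activity (a lower number here means a stronger inhibitor, a higher number a weaker inhibitor), compound 1 gives > 30000 nM, which is a limit of the assay rather than a number.
Compound 2 `CC(=O)Nc1cc(NC(=O)Nc2ccc(C)c(C)c2)ccc1C`: in this assay compound 2 gives > 30000 nM, again a limit.
Compound 3 `Cc1ccc(NC(=O)Nc2ccccc2Cl)cc1NC(=O)c1ccccc1`: in this assay compound 3 gives > 30000 nM, also a limit.

Compound 3 therefore stands at the same limit as the other two, and none of the three can be ranked against another. For the measured compounds named here, the one computed step, from compound 1 to compound 3, reads a step that the two limits leave unreadable from compound 1 to compound 3: replacing methyl with phenyl on the carbonyl carbon gave no readable change, since both ends sit at the limit of > 30000 nM in this assay, at which 3 of the 3 values shown sit. Compound 1 and compound 2 differ only in the group on the urea nitrogen, and both show a limit, so that change too is unreadable.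

Compound 4 `Cc1ccc(NC(=O)Nc2cc(Cl)cc(Cl)c2)cc1NC(=O)c1ccccc1` differs from compound 3 by 3,5-dichlorophenyl in place of 2-chlorophenyl on an amide-type nitrogen. Going by the values given here, no measured step resolves a change of this kind; every value so far is a limit. The step of a number no higher from compound 3 to compound 4 (the limit leaves the size open) is therefore expected to be unreadable as well. Compound 4 is estimated to give about 30000 nM in this assay, somewhere between 8000 nM and 100000 nM, most likely reported only as a limit.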

Compound 4, half-maximal inhibitory concentration: 259 nM
Compound 4: the middle estimate sits 120-fold (2.06 log units) above what was measured; measured number outside the range, below it.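

For the compounds shown here, the swap of 2-chlorophenyl for 3,5-dichlorophenyl on an amide-type nitrogen is the first change here that can be read in this assay, and it gives an at least 110-fold lower number from compound 3 to compound 4 (2.06 log units; beyond the scatter). The earlier compounds shown here could not show whether this position matters at all, whereas this pair shows that the group held there can decide between no readable activity and clear activity on these cells. Compound 4 also provides the only actual number in the set, a first reference against which later changes can be sized, while the rest of the series remains at the ceiling of the assay: the limit of > 30000 nM in this assay, at which 3 of the 4 values shown sit.

The swap changes both how many chlorine atoms the ring carries and where they stand, and this one pair cannot separate those two changes or explain the gain, so it remains unclear whether other groups on this ring, such as trifluoromethyl or methoxy in place of the chlorines, would serve as well. Going by these compounds, it is also open whether the phenyl on the carbonyl carbon is needed, or whether methyl or a longer chain there would keep the activity alongside the 3,5-dichlorophenyl group.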